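Series notes: aryl sulfonate change on the propyl analogue

The source may hold more compounds than are shown below. What is called first, only, known or untested is meant among the compounds shown, and "the series" means these compounds.

Going by the values given here, compound 3 `CCCN1CCN(c2ccc(S(=O)(=O)Oc3c(Cl)cc(Cl)cc3Cl)cc2)C1=O` gives 56000 nM in a functional assay on HT-29 cells (Homo sapiens) for antiproliferative activity, read by sulforhodamine B assay, with a stated time of 48 h (on this read-out higher numbers stand for weaker inhibition and lower numbers for stronger inhibition), the highest of the three numbers measured so far. Compound 1 `CN1CCN(c2ccc(S(=O)(=O)Oc3c(Cl)cc(Cl)cc3Cl)cc2)C1=O` gives 2500 nM and compound 2 `CN1CCN(c2ccc(S(=O)(=O)Oc3cccc(I)c3)cc2)C1=O` gives 590 nM in this assay. Among the compounds with values here, the one step measured within one change is a 22-fold higher number from compound 1 to compound 3 (1.35 log units; beyond the scatter), so the chain on the ring nitrogen in compound 3 accounts for its standing. Compound 4 `CCCN1CCN(c2ccc(S(=O)(=O)Oc3ccc(Cl)cc3)cc2)C1=O` keeps that chain and changes the aryl group: 4-chlorophenyl in place of 2,4,6-trichlorophenyl on an oxygen. Within the data shown here, no measured step bears directly on this aryl change. Among the measured compounds shown here, what is known is only that compound 1 with 2,4,6-trichlorophenyl and compound 2 with 3-iodophenyl differ beyond the scatter, with the smaller aryl group giving the lower number, but that pair is not a step on the same chain as compound 3. For compound 4 the expected step is a 2.2-fold lower number from compound 3 to compound 4 (0.35 log units; beyond the scatter), a moderate move toward a lower number, carried with wide uncertainty. Compound 4 is therefore estimated at 25000 nM, within a range from 6000 nM to 100000 nM.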

Compound 4, half-maximal inhibitory concentration: 15000 nM
Estimate against measurement, compound 4: 1.7-fold (0.22 log units) above; the range from low to high includes it.
By their numbers in this assay, from the lowest: compound 2; then compound 1; then compound 4; then compound 3.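

On the propyl analogue, the aryl group on the sulfonate oxygen affects the read-out in this assay, with a 3.7-fold lower number from compound 3 to compound 4 (0.57 log units; beyond the scatter) on a single chain, where the earlier aryl contrast between two compounds was not a one-place step. The change removes chlorine atoms from the aryl ring, and the number stays high on this chain, as this step is smaller than a 22-fold higher number from compound 1 to compound 3 (1.35 log units; beyond the scatter) in the same assay. No measured property accounts for the step.

From the compounds shown here alone, it remains open whether 4-chlorophenyl in place of 2,4,6-trichlorophenyl gives a step of similar size on the methyl analogue, and which chlorine atoms carry the change. Also open, going by these compounds, is how the series responds to a butyl chain on the ring nitrogen, or to an amine or a carboxylic acid on the aryl ring.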